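Swapping one side chain on compound 1

A few compounds are considered here, and "the series" means these few. Any claim that something is new, unique, unknown or untested is made for them only; others in the source may bear on it.

Within the data shown here, in an ADME assay on microsomes from liver (Rattus norvegicus) for metabolic stability, read by LC-MS, with a stated time of 10 min, tested at 0.5 uM (on this read-out lower numbers stand for a less stable compound and higher numbers for a more stable compound), compound 1 (`c1ccc2c(c1)CN[C@@H](CN(CC[C@@H]1CCCNC1)[C@H]1CCCc3cccnc31)C2`) gives 28% and stands lowest of the two numbers so far. Compound 2 (`c1cnc2c(c1)CCC[C@@H]2N(CCCN1CCNCC1)Cc1cc2ccccc2cn1`) gives 59% and that gap lies beyond the usual scatter, yet the two compounds differ in more than one place, so the gap cannot be tied to any single change. Compound 3 (`CCN1CCN(CCCN(C[C@H]2Cc3ccccc3CN2)[C@H]2CCCc3cccnc32)CC1`), still unmeasured, keeps the core of compound 1 but carries (4-ethylpiperazin-1-yl)methyl in place of piperidin-3-yl on a saturated chain carbon, two bonds along the chain from an amine nitrogen. Among the measured compounds shown here, no measured pair shows what such a swap does, so any forecast here is loose. The expected change is a number 8 percentage points higher from compound 1 to compound 3 (within the scatter) and that small rise would stay within the scatter. For compound 3 the estimated value is 36% (expected range 15% to 60%).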

Compound 3, percent of the compound remaining: 1%
For compound 3 the middle estimate is 35 percentage points above the measured one; the measured number lies below the stated range.
By their numbers in this assay, from the lowest: compound 3; then compound 1; then compound 2.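

In this assay, among these compounds, this is the first change in a single place, and it shows that the side chain at this position can move the read-out a long way with the rest of the molecule unchanged. Putting (4-ethylpiperazin-1-yl)methyl in place of piperidin-3-yl gives a number 27 percentage points lower from compound 1 to compound 3 (beyond the scatter), and almost none of compound 3 remains at 1% in the test. No available measurement explains why the number falls.

This one step swaps the ring, lengthens the side chain and adds the ethyl group all at once, so it cannot show which of these parts goes with the fall. It also leaves open where the number would land with a morpholine ring or with a piperazine ring lacking the ethyl group at this same place.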